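The compounds below may be only part of what the source reports. "The series", "measured", "known", "first", "only" and "open" are said of these compounds alone.

- Compound 1 `O=C1C=C(N2CCN(c3ccccc3Cl)CC2)C(=O)c2c(O)cccc21` gives 7200 nM
- Compound 2 `O=C1C=C(N2CCC(c3ccccc3)CC2)C(=O)c2c(O)cccc21` gives 8600 nM

In a functional assay on HeLa cells (Homo sapiens) for antiproliferative activity, read by MTT assay, with a stated time of 72 h (on this read-out lower numbers stand for stronger inhibition and higher numbers for weaker inhibition), compound 2 gives 8600 nM and stands level with compound 1 within the scatter. Compound 3 `O=C1C=C(N2CCC(c3ccc(Cl)cc3)CC2)C(=O)c2c(O)cccc21` carries one change from compound 2: chloro in place of hydrogen on an aromatic carbon, para to a large group (chloro in place of hydrogen on an aromatic carbon). Among the compounds with values here, no measured pair shows this change, so in this assay only a small step toward stronger inhibition is expected, none beyond the scatter. The estimated change is a 1.6-fold lower number from compound 2 to compound 3 (0.19 log units; within the scatter). Compound 3 is estimated at 5500 nM with a range from 2500 nM to 11000 nM expected.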

Compound 3, half-maximal inhibitory concentration: 18200 nM
Compound 3: the middle estimate sits 3.3-fold (0.52 log units) below what was measured, outside the stated range (above it).
By their numbers in this assay, from the lowest: compounds 1 and 2 (each within the scatter of the next); then compound 3.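

In this assay, the change from phenyl to 4-chlorophenyl brings a 2.1-fold higher number from compound 2 to compound 3 (0.33 log units; beyond the scatter), so chloro in place of hydrogen at this place, para to a large group, weakens inhibition, a modest step beyond the scatter. Within the data shown here, this single pair is the first reading of any change at this position. Nothing available explains the loss of inhibition. The compounds shown leave open whether fluoro, methoxy or an amine at this same place would also weaken inhibition, or whether the step is particular to chloro.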